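The source may hold more compounds than are shown below. What is called first, only, known or untested is meant among the compounds shown, and "the series" means these compounds.

Compound 1, `Nc1[nH]c(C(=O)c2ccccc2)c(-c2ccc(Cl)cc2Cl)c1C(=O)c1ccccc1`: in an assay for inhibition of Polyunsaturated fatty acid lipoxygenase ALOX15 (Homo sapiens), with a stated time of 10 min (a lower number here means a stronger inhibitor, a higher number a weaker inhibitor), compound 1 gives only the limit > 100000 nM.
Compound 2, `Nc1[nH]c(C(=O)c2ccccc2)c(-c2c(F)cccc2F)c1C(=O)c1ccc(Cl)c(Cl)c1`: in this assay compound 2 gives only the limit > 100000 nM.
Compound 3, `NC(=O)c1c(N)[nH]c(C(=O)c2ccccc2)c1-c1ccc(Cl)cc1Cl`: in this assay compound 3 gives only the limit > 100000 nM.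

Compound 3 thus stands at the limit of this assay, as do the two other values shown, (the limit of > 100000 nM in this assay, at which 3 of the 3 values shown sit). Going by the values given here, the single one-point step measured, a step that the two limits leave unreadable from compound 1 to compound 3, is unreadable, both of its ends being limits. Compound 4, `Nc1[nH]c(C(=O)c2ccccc2)c(-c2ccc(Cl)cc2Cl)c1C(=O)c1cccs1`, differs from compound 3 by thiophen-2-yl in place of amino on a carbonyl carbon. Among the compounds with values here, no measured step reads on this change; the limits give neither a size nor a direction, so nothing beyond the scatter can be predicted. The step that the limit leaves unreadable from compound 3 to compound 4 is expected to remain unresolved. Compound 4 is expected near 150000 nM, between 30000 nM and 1000000 nM, most likely again as a limit in this assay.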

Compound 4, half-maximal inhibitory concentration: > 100000 nM
Compound 4 was reported as a limit; the forecaster's own chance of this, stated with the estimate: 75%; the middle value lies beyond the limit too.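

The steps linking compound 4 to compound 3 and to compound 1 cannot be read, as each end is a limit: the limit of > 100000 nM in this assay, at which 4 of the 4 values shown sit.

The compounds shown leave open which change to the shared core, if any, would give a readable value in this assay.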